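This account rests on a few compounds, and the source may have more. Where it says the series, first, only, none or still open, it means among the compounds named here.

Compound 1 `c1ccc(CNCCCCN(C[C@H]2Cc3ccccc3CN2)[C@H]2CCCc3cccnc32)cc1`: > 30000 nM
Compound 2 `c1ccc2c(c1)CN[C@@H](CN(CCCCNCC1CCCCC1)[C@H]1CCCc3cccnc31)C2`: > 30000 nM
Compound 3 `O=S1(=O)CCC(NCCCCN(C[C@H]2Cc3ccccc3CN2)[C@H]2CCCc3cccnc32)CC1`: > 30000 nM

The three compounds share one core and differ only in the group carried on one amine nitrogen. In a functional assay on cells for agonist activity at C-X-C chemokine receptor type 4 (Homo sapiens), read by fluorescence and calcium flux, with a stated time of 90 s (on this read-out higher numbers stand for an effect only at larger amounts of compound and lower numbers for an effect already at smaller amounts), compound 1 gives > 30000 nM, which is a limit of the assay and not a number. Compound 2 also stops at a limit, > 30000 nM. Compound 3 likewise reaches only a limit, > 30000 nM. Going by the values given here, because every value sits at the limit of > 30000 nM in this assay, at which 3 of the 3 values shown sit, none of the measured steps can be read: a step that the two limits leave unreadable from compound 1 to compound 2 is hidden, as are a step that the two limits leave unreadable from compound 1 to compound 3 and a step that the two limits leave unreadable from compound 2 to compound 3.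

Compound 4 `CC1(C)CCC(NCCCCN(C[C@H]2Cc3ccccc3CN2)[C@H]2CCCc3cccnc32)CC1` has not been measured. It differs from compound 1 in one place: 4,4-dimethylcyclohexyl in place of benzyl on an amine nitrogen. The nearest measured step is the one in which cyclohexyl replaced phenyl on a saturated chain carbon bound to an amine nitrogen, and that step was unreadable. Among the compounds with values here, nothing among the measured compounds therefore points toward a readable effect, and compound 4 is expected to remain at the limit as well. The expected step is a number no higher from compound 1 to compound 4 (the limit leaves the size open), meaning no readable change. Compound 4 is estimated at 30000 nM, with a range from 10000 nM to 100000 nM, most probably reported as a limit only.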

Compound 4, half-maximal effective concentration: > 30000 nM
Compound 4: a limit, no number (the forecaster's own chance of this, stated with the estimate: 85%); the middle value lies on the limit itself.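

In this assay compound 4 gives > 30000 nM, which is a limit of the assay and not a number. Going by these compounds alone, no step between compound 4 and compound 1, compound 2 or compound 3 can be read: the limit of > 30000 nM in this assay, at which 4 of the 4 values shown sit. The compounds shown leave open whether any group on this amine nitrogen gives a measurable effect in this assay, and how the four compounds rank.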